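Methoxy for bromo on the pendant phenyl of compound 3

A few compounds are considered here, and "the series" means these few. Any claim that something is new, unique, unknown or untested is made for them only; others in the source may bear on it.

Compound 3 `O=[N+]([O-])c1ccc(CN2CCC(n3cc(CC(OCc4cc(-c5ccccc5Br)no4)c4ccc(Br)cc4)nn3)CC2)cc1` is assessed in a functional assay on MDA-MB-231 cells (Homo sapiens) for cytotoxicity, with a stated time of 48 h; on this read-out higher numbers stand for weaker inhibition and lower numbers for stronger inhibition. In this assay compound 3 gives > 25000 nM, which is a limit of the assay and not a number. Compound 1 `N#Cc1ccc(-c2cc(COC(Cc3cn(C4CCN(Cc5ccc([N+](=O)[O-])cc5)CC4)nn3)c3ccc(Br)cc3)on2)cc1` carries 4-cyanophenyl where compound 3 carries 2-bromophenyl. In this assay compound 1 gives > 25000 nM, a limit. Compound 2 `N#Cc1cccc(-c2cc(COC(Cc3cn(C4CCN(Cc5ccc([N+](=O)[O-])cc5)CC4)nn3)c3ccc(Br)cc3)on2)c1` carries 3-cyanophenyl at that place. In this assay compound 2 gives > 25000 nM, likewise a limit. All three values sit at the limit of > 25000 nM in this assay, at which 3 of the 3 values shown sit, so compound 3 stands level with the other two and no order among them can be read. The steps a step that the two limits leave unreadable from compound 1 to compound 2, a step that the two limits leave unreadable from compound 1 to compound 3 and a step that the two limits leave unreadable from compound 2 to compound 3 are unreadable because both ends of each sit at the limit of > 25000 nM in this assay, at which 3 of the 3 values shown sit.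

Compound 4 `COc1ccccc1-c1cc(COC(Cc2cn(C3CCN(Cc4ccc([N+](=O)[O-])cc4)CC3)nn2)c2ccc(Br)cc2)on1` differs from compound 3 by methoxy in place of bromo on an aromatic carbon. Within the data shown here, the three measured steps concern the same pendant group, yet none yields a readable size, so no measured step shows that changing this group moves the read-out off the limit. The step that the limit leaves unreadable from compound 3 to compound 4 is therefore estimated as none beyond the scatter. Compound 4 is expected to give 30000 nM in this assay, within 8000 nM to 100000 nM, and most likely to be reported once more as a limit.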

Compound 4, half-maximal inhibitory concentration: > 25000 nM
Compound 4 ended at the assay's limit (the forecaster's own chance of this, stated with the estimate: 80%); the middle value lies beyond the limit too.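

No new step can be read between compound 4 and compound 1, compound 2 or compound 3 in this assay, because all four values are limits and not numbers: the limit of > 25000 nM in this assay, at which 4 of the 4 values shown sit.

The compounds shown leave open whether any change on the pendant phenyl moves the read-out off this limit, and where the true values of these four compounds lie.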